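The source may report more compounds than this note shows. Statements on the series, on what has been measured and on what is new or still open speak of the compounds shown alone.

In an in vivo ADME assay on the whole organism (Cavia porcellus) (a lower number here means that the compound disappears faster, a higher number that the compound lasts longer), compound 1 `CCCCC(NC(=O)c1ccc(C(=N)N)cc1)C(C)(C)C(=O)N1CCC(CC(=O)O)CC1` gives 1.03 h and compound 2 `CCCCCC(NC(=O)c1ccc(C(=N)N)cc1)C(C)(C)C(=O)N1CCC(CC(=O)O)CC1` gives 0.517 h. The change between them is methyl in place of hydrogen on a saturated chain carbon, five bonds along the chain from an amide-type nitrogen, and it produced a 2.0-fold lower number from compound 1 to compound 2 (0.30 log units; within the scatter). Compound 3 `CC(NC(=O)c1ccc(C(=N)N)cc1F)C(C)(C)C(=O)N1CCC(CC(=O)O)CC1` gives 1.4 h in this assay; how its core differs from that of compound 1 is not broken down here. Compound 4 `CCC(NC(=O)c1ccc(C(=N)N)cc1F)C(C)(C)C(=O)N1CCC(CC(=O)O)CC1` carries the change methyl in place of hydrogen on a saturated chain carbon, two bonds along the chain from an amide-type nitrogen relative to compound 3. Among the measured compounds shown here, this is the same kind of change as the one from compound 1 to compound 2, but not the same: there the new methyl sat five bonds along the chain from an amide-type nitrogen, here it sits two bonds along the chain from an amide-type nitrogen. Because compound 1 gave 1.03 h and compound 2 gave 0.517 h, a step of similar modest size is expected, a 1.4-fold lower number from compound 3 to compound 4 (0.15 log units; within the scatter). Compound 4 is thus estimated at 1 h, expected between 0.5 h and 2 h.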

Compound 4, half-life: 1.48 h
For compound 4 the middle estimate is 1.5-fold (0.17 log units) below the measured one; measured number inside the range.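

In this assay, methyl in place of hydrogen on a saturated chain carbon, two bonds along the chain from an amide-type nitrogen, gives a 1.1-fold higher number from compound 3 to compound 4 (0.02 log units; within the scatter) and so stays small on this core. Set beside the earlier step, the two do not differ beyond the scatter: the same change on two cores in this assay, a 2.0-fold lower number (0.30 log units; within the scatter) from compound 1 to compound 2 and a 1.1-fold higher number (0.02 log units; within the scatter) from compound 3 to compound 4, 2.1-fold (0.32 log units) apart, within the scatter of two such steps. Among the compounds shown here, this shows only that neither core gives a step beyond the scatter; it does not show that the change behaves alike across the series, for the new methyl sits at a different place in each pair and there are only two pairs.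

The compounds shown leave open what a longer chain, a hydroxyl group or an amine at that carbon would do to the half-life on the core of compound 3. They also leave open how a methyl five bonds along the chain would read on that core.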